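Fluoro for methoxy on the bromopropanamide anilide series

A few compounds are considered here, and "the series" means these few. Any claim that something is new, unique, unknown or untested is made for them only; others in the source may bear on it.

Measured compounds, with the result in a functional assay on MOLT-3 cells (Homo sapiens) for antiproliferative activity; a higher number here means a weaker inhibitor, a lower number a stronger inhibitor:

- compound 1 `COc1ccc(C(=O)Nc2cc(OC)c(OC)c(OC)c2)cc1NC(=O)C(C)Br`: 4240 nM
- compound 2 `COc1cc(NC(=O)c2ccc(F)c(NC(=O)C(C)Br)c2)cc(OC)c1OC`: 2200 nM
- compound 3 `COc1ccc(NC(=O)c2cccc(NC(=O)C(C)Br)c2)cc1`: 800 nM

Compound 3 stands lowest of the three numbers in this assay; compound 2 is nearest, compound 1 furthest, both beyond the scatter.

Compound 1 and compound 2 differ in one place, (fluoro in place of methoxy on an aromatic carbon), and the step is a 1.9-fold lower number from compound 1 to compound 2 (0.28 log units; within the scatter), so within the scatter.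

Compound 4 `CC(Br)C(=O)Nc1cccc(C(=O)Nc2ccc(F)cc2)c1` is not yet measured. It is made from compound 3 by the same kind of change, (fluoro in place of methoxy on an aromatic carbon). The place is not the same word for word: from compound 1 to compound 2 the site is ortho to a ((1-bromoethyl)carbonyl)amino group (6 heavy atoms) and para to a large group, whereas from compound 3 to compound 4 it is only para to a large group. The difference between the core of compound 1 and the core of compound 3 is not broken down here.

With one earlier example of this kind of change, and that one within the scatter, compound 4 is expected to sit close to compound 3 in this assay, with a step of about a 1.3-fold lower number from compound 3 to compound 4 (0.12 log units; within the scatter), resting on the near-flat step a 1.9-fold lower number from compound 1 to compound 2 (0.28 log units; within the scatter). Compound 4 is estimated at 600 nM in this assay, between 250 nM and 1500 nM.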

Compound 4, half-maximal inhibitory concentration: 2000 nM
The estimate for compound 4 lay 3.3-fold (0.52 log units) below the measured number; the whole stated range lies below it.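

In this assay, fluoro in place of methoxy on an aromatic carbon para to a large group gives a 2.5-fold higher number from compound 3 to compound 4 (0.40 log units; beyond the scatter) and so counts as a modest loss of activity on the core of compound 3. Set beside the earlier example, the change does not carry over as a fixed step between these two cores: the same change on two cores in this assay, a 1.9-fold lower number (0.28 log units; within the scatter) from compound 1 to compound 2 and a 2.5-fold higher number (0.40 log units; beyond the scatter) from compound 3 to compound 4, 4.8-fold (0.68 log units) apart, beyond the scatter of two such steps

Among the compounds shown here, this pair of steps shows that a near-flat result on the core of compound 1 is a poor guide to the result on the core of compound 3, but it does not separate the part played by the core from the part played by the different surroundings of the changed site, and with only two examples it gives no rule for the direction of the step on any further core.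

Still open, going by these compounds, is whether other groups at the same site of the core of compound 3, such as chloro, methyl, hydroxy or an amine, stay close to compound 3 or close to compound 4 in this assay. Also open, on these data alone, is whether the difference between the two steps persists when the bromo-bearing side chain gives way to a longer chain.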